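The compounds below may be only part of what the source reports. "The series", "measured", "known", "first", "only" and "open" are said of these compounds alone.

Measured compounds:
compound 1, `CC1CC/C(=N\Nc2ccc(Br)cc2)c2ncc(C(=O)O)c(=O)n21`, in a functional assay on the whole organism for inhibition, with Rattus norvegicus as the target (a higher number here means that more compound is needed for the effect, a lower number that less compound is needed), gives > 1000 umol/kg, which is a limit of the assay and not a number.
compound 2, `CC1CC/C(=N\Nc2ccc(C(F)(F)F)cc2)c2ncc(C(=O)O)c(=O)n21`, gives > 1000 umol/kg, again a limit and not a number.
compound 3, `CCCCc1ccc(N/N=C2\CCC(C)n3c2ncc(C(=O)O)c3=O)cc1`, gives 100 umol/kg.

Among the compounds with values here, compound 3 thus stands alone among the three measured compounds: it is the only one with a number, the other two sitting at the limit of > 1000 umol/kg in this assay, at which 2 of the 3 values shown sit. The two steps that lead to it both point the same way. an at least 10-fold lower number from compound 1 to compound 3 (1.00 log units; beyond the scatter), and an at least 10-fold lower number from compound 2 to compound 3 (1.00 log units; beyond the scatter). The step between compounds 1 and 2 cannot be read, because both values are limits.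

Compound 4, `CC1CC/C(=N\Nc2ccc(CC(=O)O)cc2)c2ncc(C(=O)O)c(=O)n21`, differs from compound 3 in one place: carboxy in place of propyl on a saturated chain carbon bound to an aromatic carbon. Within the data shown here, no measured step touches a carboxy group on this chain; the only measured steps concern the butyl itself, and both say that removing it for bromo or trifluoromethyl returns the compound to the limit. Cutting the butyl down to carboxymethyl removes most of what set compound 3 apart, so a higher number is expected for compound 4, the step of a 5.0-fold higher number from compound 3 to compound 4 (0.70 log units; beyond the scatter) being the estimate. The value for compound 4 is expected near 500 umol/kg, within 120 umol/kg to 1000 umol/kg, with a fair chance that this assay again reports only a limit.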

Compound 4, dose for 50% inhibition: > 100 umol/kg
Compound 4: no number, only a limit (the forecaster's own chance of this, stated with the estimate: 55%); the middle value does not contradict the limit.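

In this assay, the exchange of carboxy for propyl on a saturated chain carbon bound to an aromatic carbon gives a number no lower from compound 3 to compound 4 (the limit leaves the size open), so the butyl of compound 3 has now been changed at its far end and not only replaced as a whole. The earlier steps shown here showed only that bromo and trifluoromethyl, set in place of butyl, end at a limit; this one shows that a chain kept on the aromatic carbon, here carboxymethyl, does not bring a lower number than butyl. The steps that link compound 4 to compound 1 and compound 2 cannot be read, since each joins two limits, and the limit of compound 4 is set at a different level from theirs, so the three cannot be ranked.

On these data alone, how much higher the true value of compound 4 lies than that of compound 3 stays open, and it could still lie close to it. Also open, as far as these compounds go, is what a longer chain such as hexyl, or an amine or a methyl ester at the end of the chain, would do at this place.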